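The compounds below may be only part of what the source reports. "The series", "measured", "known", "first", "only" and "open" are said of these compounds alone.

Of the compounds shown here, three built on one shared core have been measured in an assay on isolated protein (strain albino) for antagonist activity at Voltage-dependent L-type calcium channel subunit alpha-1C (Cavia porcellus); on this read-out higher numbers stand for weaker inhibition and lower numbers for stronger inhibition. Compound 1 `CCOC(=O)C1=C(C)NC(C)=C(C(=O)OCC)C1c1cnc(SC)n1Nc1ccccc1` gives 1.69 nM. Compound 2 `CCOC(=O)C1=C(C)NC(C)=C(C(=O)OC)C1c1cnc(SC)n1Nc1ccccc1` gives 1.66 nM, and between them there is a 1.0-fold lower number from compound 1 to compound 2 (0.01 log units; within the scatter). Compound 3 `CCOC(=O)C1=C(C)NC(C)=C(C(=O)OCCOC)C1c1cnc(SC)n1Nc1ccccc1` gives 2.91 nM. Of the three numbers, compound 3 shows the largest, yet the gaps are small: a 1.7-fold higher number from compound 1 to compound 3 (0.24 log units; within the scatter) and a 1.8-fold higher number from compound 2 to compound 3 (0.24 log units; within the scatter).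

Compound 4 `CCOC(=O)C1=C(C)NC(C)=C(C(=O)OCCCc2ccccc2)C1c1cnc(SC)n1Nc1ccccc1` has not yet been measured. It differs from compound 3 by benzyl in place of methoxy on a saturated chain carbon, two bonds along the chain from an oxygen next to a carbonyl group. The measured steps that bear on this all sit on the same chain attached to the oxygen next to a carbonyl group, and every one of them stayed within the scatter, so the three changes made there so far have barely moved the number. For the measured compounds named here, the change to compound 4 is larger than any of those, and no measured step puts an aromatic ring on that chain, so the expectation rests only on the small earlier steps. Compound 4 is therefore expected to give about 3.2 nM, with a range from 1.2 nM to 8.5 nM, which means an expected step of a 1.1-fold higher number from compound 3 to compound 4 (0.04 log units; within the scatter) in this assay.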

Compound 4, half-maximal inhibitory concentration: 2.54 nM
Estimate against measurement, compound 4: 1.3-fold (0.10 log units) above; measured number inside the range.
By their numbers in this assay, from the lowest: compounds 2, 1, 4 and 3 (each within the scatter of the next).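

Compound 4 shows that this position takes a six-membered aromatic ring of carbon only without a step beyond the scatter: benzyl in place of methoxy, on a saturated chain carbon two bonds along the chain from an oxygen next to a carbonyl group, gives a 1.1-fold lower number from compound 3 to compound 4 (0.06 log units; within the scatter) in this assay. The 3-phenylpropyl chain also stays close to the two shortest chains, with a 1.5-fold higher number from compound 2 to compound 4 (0.18 log units; within the scatter) and a 1.5-fold higher number from compound 1 to compound 4 (0.18 log units; within the scatter), so neither the added heavy atoms nor the lost hydrogen-bond acceptor of methoxy moved the number beyond the scatter. No measurement here explains why the number stays so flat.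

On these data alone, whether this holds for an amine or a carboxylic acid at the end of this chain remains open. As far as these compounds go, all four compounds share the rest of the core, so the effect of changes elsewhere also remains open.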